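Ring size at the amide: from compound 2 to compound 4

This account rests on a few compounds, and the source may have more. Where it says the series, first, only, none or still open, it means among the compounds named here.

Measured so far:
compound 1 `O=C(C1CC1)N1CC2CC1CN2` — 10000 nM
compound 2 `O=C(C1CCC1)N1CC2CC(C1)N2` — 240 nM
compound 3 `O=C(C1CC=CC1)N1CC2CC(C1)N2` — 1100 nM

Of the compounds shown here, three have been tested in an assay on CHO cells for displacement of a labelled ligand from Neuronal acetylcholine receptor; alpha3/alpha6/beta2/beta3 (Homo sapiens), read by scintillation counting; on this read-out higher numbers stand for weaker inhibition and lower numbers for stronger inhibition. Compound 2 stands lowest of the three numbers. The nearest is compound 3, whose value in this assay, 1100 nM, lies beyond the scatter above that of compound 2. The furthest is compound 1, whose value of 10000 nM lies far beyond the scatter above it. No two of the three differ in only one place, so the values are noted side by side without a single step being read from any pair.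

The next compound, compound 4 `C[C@H]1C[C@@H]1C(=O)N1CC2CC(C1)N2`, has not yet been measured. Compared with compound 2 the change is 2-methylcyclopropyl in place of cyclobutyl on a carbonyl carbon. The two share the same atoms joined differently.

Going by the values given here, no measured pair shows what such a change of ring size does on this core, so the expectation rests on compound 2 alone. Compound 4 is expected to sit close to compound 2, with a step of a 1.7-fold higher number from compound 2 to compound 4 (0.22 log units; within the scatter) that may run a little towards weaker binding but could fall within the scatter. The estimate for compound 4 in this assay is 400 nM, with a range from 120 nM to 1500 nM.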

Compound 4, inhibition constant: 310 nM
For compound 4 the middle estimate is 1.3-fold (0.11 log units) above the measured one; low and high end bracket the measured number.
By their numbers in this assay, from the lowest: compounds 2 and 4 (each within the scatter of the next); then compound 3; then compound 1.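

In this assay, going by these compounds alone, putting 2-methylcyclopropyl in place of cyclobutyl on a carbonyl carbon gives a 1.3-fold higher number from compound 2 to compound 4 (0.11 log units; within the scatter), the only step in this set that can be read from a pair differing in one place. It shows that, on the core of compound 2, these two groups of equal heavy-atom count, one with a four-membered ring of carbon and the other with a three-membered ring of carbon, cannot be told apart by this read-out, so this one rearrangement of the atoms on the carbonyl carbon leaves the value within the usual scatter. Nothing at hand bears on why the two values stay so close.

Within the data shown here, the single pair leaves open whether the two defined stereocentres of the 2-methylcyclopropyl group matter, since compound 4 represents only one arrangement of them. It also leaves open how far this tolerance extends on the carbonyl carbon: whether an open-chain butyl group, a longer chain, an amine or a carboxylic acid there would stay within the scatter of compound 2 or move clearly away from it.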